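Methylating a Ring Amine on Two Bridged Cores

This account rests on a few compounds, and the source may have more. Where it says the series, first, only, none or still open, it means among the compounds named here.

Compound 1 `Fc1ccc(C2=CC3CNCC(C2)C3)cn1` is the reference point of this small set. In an in vitro functional assay on SH-EP1 cells for agonist activity at Neuronal acetylcholine receptor; alpha4/beta2 (Homo sapiens), read by FLIPR and calcium flux (on this read-out higher numbers stand for larger maximal responses and lower numbers for smaller maximal responses), compound 1 gives 104%. Compound 2 `CN1CC2C=C(c3ccc(F)nc3)CC(C2)C1` differs from it in one place only: methyl in place of hydrogen on an amine nitrogen in a ring. In this assay compound 2 gives 22%, and the step of a number 82 percentage points lower from compound 1 to compound 2 (beyond the scatter) shows how much of the maximal response is lost when that single methyl is added to the ring nitrogen.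

Compound 3 `CC(C)Oc1cncc(C2=CC3CNCC(C2)C3)c1` carries a different aromatic part on a bridged amine; the difference between its core and the core of compound 1 is not broken down here. In this assay compound 3 gives 75%, which places it second among the three measured numbers, below compound 1 and well above compound 2.

Compound 4 `CC(C)Oc1cncc(C2=CC3CC(C2)CN(C)C3)c1` stands to compound 3 as compound 2 stands to compound 1: methyl in place of hydrogen on an amine nitrogen in a ring. The place of the change is described in identical words for both pairs, so it is the same change, made on a second core. Within the data shown here, since the only measured example of this change, the step of a number 82 percentage points lower from compound 1 to compound 2 (beyond the scatter), is large, a fall of the same kind is expected here as well, a number 57 percentage points lower from compound 3 to compound 4 (beyond the scatter). Compound 3 starts from a lower number than compound 1, so in absolute points the fall cannot be quite as deep. On that basis compound 4 is expected to give about 18% in this assay, with a likely range from 5% to 40%.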

Compound 4, largest response reached (reported as percent of maximum), in percent of the reference or control that the assay uses: 1%
Estimate against measurement, compound 4: 17 percentage points above, and the stated range ends above it.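

In this assay, methyl in place of hydrogen on an amine nitrogen in a ring again removes most of the maximal response, with a number 74 percentage points lower from compound 3 to compound 4 (beyond the scatter). Set beside the earlier step, the change carries over to the second structure with much the same size, even though the starting numbers and the aromatic parts of the two pairs differ: the same change on two cores in this assay, a number 82 percentage points lower (beyond the scatter) from compound 1 to compound 2 and a number 74 percentage points lower (beyond the scatter) from compound 3 to compound 4, 8 percentage points apart, within the scatter of two such steps. This shows agreement between two matched pairs in a single read-out, which is useful for a first forecast but is not a rule for the whole series, and it does not show why a single methyl has so large an effect.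

The compounds shown leave open whether a different group on the same ring nitrogen, such as ethyl, a longer chain or acetyl, would lower the response as methyl does. They also leave open whether the same step would appear with other aromatic parts, for example one carrying an amine or a carboxylic acid, since only the two aromatic parts seen here have been compared.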